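Chloro to phenethyl in a cytotoxicity series

A few compounds are considered here, and "the series" means these few. Any claim that something is new, unique, unknown or untested is made for them only; others in the source may bear on it.

These notes cover an ADME assay on HEK293 cells (Homo sapiens) for cytotoxicity, with a stated time of 6 h (on this read-out higher numbers stand for lower toxicity in this test and lower numbers for higher toxicity in this test), for three measured compounds and one still to be tested. Compound 1 `CCNc1nc(N)nc2ccccc12` gives > 25000 nM, which is a limit of the assay. Compound 2 `CCCCNc1nc(N)nc2ccc(CCc3ccccn3)cc12` gives > 18000 nM, which is also a limit. Among the compounds with values here, compound 3 `CCCCNc1nc(N)nc2cccc(Cl)c12` gives 100 nM, the only actual number of the three and the only reading that shows a half-maximal cytotoxic concentration within the range tested.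

Compound 4 `CCCCNc1nc(N)nc2cccc(CCc3ccccc3)c12` differs from compound 3 in one place: phenethyl in place of chloro on an aromatic carbon. This puts phenethyl in place of chloro on an aromatic carbon, so the substituent grows while the rest of the structure stays the same.

Within the data shown here, no measured pair in the set differs at a single place, so the size of this change cannot be read directly from the data. Compound 3 at 100 nM stands alone as a low reading, so a return toward lower toxicity in this assay is expected, beyond the scatter but poorly defined in size. The expected change is a 30-fold higher number from compound 3 to compound 4 (1.48 log units; beyond the scatter), in the direction of higher numbers. For compound 4 the estimate is 3000 nM, with an expected range of 250 nM to 25000 nM.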

Compound 4, half-maximal cytotoxic concentration: > 25000 nM
Compound 4 gave a limit, no number; the forecaster's own chance of this, stated with the estimate: 30%; middle value at least 8.3-fold (0.92 log units) away from the limit.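

Within the data shown here, the change to phenethyl in place of chloro on an aromatic carbon gives an at least 250-fold higher number from compound 3 to compound 4 (2.39 log units; beyond the scatter) in this assay, and this is the first step that can be read between compounds differing in one place. The low reading of compound 3 therefore does not come from the rest of the structure alone, since compound 4 keeps all of it and differs only in the group on this aromatic carbon, ortho to a fused ring and meta to a fused ring. Compound 4 reads as a limit, so the step fixes only the smallest possible size of the change and the real size stays unknown: the limit of > 25000 nM in this assay, at which 2 of the 4 values shown sit.

The compounds shown leave open whether the low reading is particular to chloro or would also appear with fluoro, bromo or methyl on this carbon. They also leave open whether the full phenethyl is needed for the high reading, or whether a shorter group such as ethyl, or a chain ending in an amine, would read the same way in this assay.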